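The compounds below may be only part of what the source reports. "The series", "measured", "known", "first", "only" and "open" are said of these compounds alone.

Compound 3 `COc1cc2c(Oc3ccc(NC(=O)c4nccc(-c5ccc(F)cc5)n4)cc3F)ccnc2cc1OCCCN1CCN(C)CC1` and compound 4 `COc1cc2c(Oc3ccc(NC(=O)c4nccc(-c5ccc(F)cc5F)n4)cc3F)ccnc2cc1OCCCN1CCN(C)CC1` share one core; how that core differs from the core of compound 2 `COc1cc2c(Oc3ccc(NC(=O)c4cc(-c5ccccc5)ccn4)cc3F)ccnc2cc1OCCCN1CCCCC1` and compound 1 `COc1cc2c(Oc3ccc(NC(=O)c4cc(-c5ccc(F)cc5)ccn4)cc3F)ccnc2cc1OCCCN1CCCCC1` is not broken down here. In a functional assay on A549 cells (Homo sapiens) for cytotoxicity, read by MTT assay, with a stated time of 72 h (a lower number here means a stronger inhibitor, a higher number a weaker inhibitor), compound 3 gives 680 nM, compound 2 gives 1800 nM and compound 1 gives 10100 nM. The change from compound 2 to compound 1 is fluoro in place of hydrogen on an aromatic carbon and it made a 5.6-fold higher number from compound 2 to compound 1 (0.75 log units; beyond the scatter). The change from compound 3 to compound 4 is fluoro in place of hydrogen on an aromatic carbon, the same kind of change, though here the place is ortho to a large group and meta to a fluoro group rather than para to a large group. Because a 5.6-fold higher number from compound 2 to compound 1 (0.75 log units; beyond the scatter) went toward a weaker inhibitor, compound 4 is expected to give a higher number than its parent. The estimated step is a 2.9-fold higher number from compound 3 to compound 4 (0.47 log units; beyond the scatter). The two places are not the same, which weighs toward a smaller step than the earlier one. The expected value for compound 4 is 2000 nM, estimated to fall between 600 nM and 7000 nM.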

Compound 4, half-maximal inhibitory concentration: 660 nM
Beside the measured number, compound 4's estimate is 3.0-fold (0.48 log units) above it; low and high end bracket the measured number.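

In this assay, replacing 4-fluorophenyl with 2,4-difluorophenyl gave a 1.0-fold lower number from compound 3 to compound 4 (0.01 log units; within the scatter), so this fluoro step left the reading effectively unchanged. Set beside the earlier fluoro step, the effect did not carry from one core to the other: the same change on two cores in this assay, a 5.6-fold higher number (0.75 log units; beyond the scatter) from compound 2 to compound 1 and a 1.0-fold lower number (0.01 log units; within the scatter) from compound 3 to compound 4, 5.8-fold (0.76 log units) apart, beyond the scatter of two such steps. The two steps differ both in the core and in the place of the fluoro group, and these compounds cannot separate those two differences, so the cause of the gap remains unknown.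

The compounds shown leave open whether a 2,4-difluorophenyl group on the core of compound 2 would read more like compound 1 or like compound 2. They also leave open how a chloro or a methyl group at the new place would read on the core of compound 3.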